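Fibroblast Cytotoxicity of Bis-Benzylidene Cyclohexanones: From Chloro to Hydroxy-Methoxy

This account rests on a few compounds, and the source may have more. Where it says the series, first, only, none or still open, it means among the compounds named here.

Compound 1 `COc1cccc(/C=C2\CCC/C(=C\c3ccc(Br)cc3)C2=O)c1OC` — 21400 nM
Compound 2 `COc1ccc(/C=C2\CCC/C(=C\c3cccc(OC)c3OC)C2=O)c(OC)c1` — > 50000 nM
Compound 3 `COc1ccc(/C=C2\CCC/C(=C\c3ccccc3Cl)C2=O)cc1OC` — 21600 nM

Of the compounds shown here, three sharing one core have been tested in an ADME assay on NHDF cells (Homo sapiens) for cytotoxicity, read by MTT assay, with a stated time of 72 h; on this read-out higher numbers stand for weaker inhibition and lower numbers for stronger inhibition. Compound 1 gives 21400 nM and compound 3 gives 21600 nM; the two numbers lie within the usual scatter of each other, so neither can be called stronger or weaker. For compound 2 this assay reports only a limit, (the limit of > 50000 nM in this assay, at which 1 of the 3 values shown sits), not a number. So the two compounds that gave numbers sit close together, and compound 3 stands beside compound 1 with no separation beyond the scatter.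

Compound 4 `COc1cc(/C=C2\CCC/C(=C\c3ccc(OC)c(OC)c3)C2=O)ccc1O` is yet to be measured in this assay. It differs from compound 3 by the change (4-hydroxy-3-methoxyphenyl in place of 2-chlorophenyl on a double-bonded chain carbon bound to a double-bonded ring carbon). For the measured compounds named here, no measured pair shows a comparable change, so no step size can be read off. The expectation is a step of a 1.6-fold higher number from compound 3 to compound 4 (0.21 log units; within the scatter) toward weaker inhibition, small and perhaps within the scatter, since compound 2 with its methoxy-rich groups gave only a limit. Compound 4 is therefore estimated at 35000 nM, within 15000 nM to 60000 nM.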

Compound 4, half-maximal inhibitory concentration: 13700 nM
For compound 4 the middle estimate is 2.6-fold (0.41 log units) above the measured one; the whole stated range lies above it.
By their numbers in this assay, from the lowest: compounds 4, 1 and 3 (each within the scatter of the next). At a limit, above all of these: compound 2.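

In this assay, the series gives its first readable step between compounds that differ in one place: a 1.6-fold lower number from compound 3 to compound 4 (0.20 log units; within the scatter) stands for the exchange of 2-chlorophenyl for 4-hydroxy-3-methoxyphenyl. This shows that, on a double-bonded chain carbon bound to a double-bonded ring carbon, a chlorine-bearing ring can give way to one with a hydrogen-bond donor and hydrogen-bond acceptors without a change beyond the usual scatter. No measurement shown explains this result.

The hydroxy and methoxy groups enter together, so this single step cannot separate what each contributes on its own. It also leaves open whether the same tolerance would hold for a ring carrying an amine or a carboxylic acid at this place.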